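The compounds below may be only part of what the source reports. "The series", "measured", "known", "first", "only" and "open" are said of these compounds alone.

Compound 1 `O=C(Nc1cccc(-n2cc(-c3ccncc3)c(-c3cc(O)cc(Cl)c3)n2)c1)Nc1ccc(Cl)c(C(F)(F)F)c1` is one of two measured compounds. In a functional assay on SNB-19 cells (Homo sapiens) for inhibition, read by sulforhodamine B assay, with a stated time of 48 h, tested at 0.01 uM (on this read-out higher numbers stand for a weaker effect at the one concentration tested and lower numbers for a stronger effect), compound 1 gives 95%. Going by the values given here, its only neighbour on the numbers, compound 2 `O=C(Nc1cccc(-n2cc(-c3ccncc3)c(-c3cc(O)cc(Cl)c3)n2)c1)Nc1ccc(Cl)c(Cl)c1`, gives 97%, and the step of a number 2 percentage points higher from compound 1 to compound 2 (within the scatter) reflects chloro in place of trifluoromethyl on an aromatic carbon. Compound 3 `COc1cc(Cl)cc(-c2nn(-c3cccc(NC(=O)Nc4ccc(Cl)c(C(F)(F)F)c4)c3)cc2-c2ccncc2)c1` differs from compound 1 by methyl in place of hydrogen on an oxygen on an aromatic ring. Among the compounds with values here, no measured step touches this hydroxy to methoxy change, and the single step known is within the scatter, so no step beyond the scatter is expected here: no change at the digits printed from compound 1 to compound 3 (within the scatter). Compound 3 is therefore estimated at 95%, between 85% and 100%.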

Compound 3, a percentage reported as activity, at one concentration (the size of the read-out at that concentration, not a potency): 92%
Compound 3: middle estimate off by 3 percentage points, on the high side; the measured number falls inside the stated range.
By their numbers in this assay, from the lowest: compounds 3, 1 and 2 (each within the scatter of the next).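

In this assay, methyl in place of hydrogen on the oxygen gives a number 3 percentage points lower from compound 1 to compound 3 (within the scatter), so hydroxy and methoxy cannot be told apart at this position on the 3-chloro-5-hydroxyphenyl group. Going by these compounds alone, the only earlier step concerned a different place, the swap of trifluoromethyl for chloro, so this is the first reading at this position. No measurement shown explains this result.

The compounds shown leave open whether an amine, a carboxylic acid or a longer chain on this oxygen would move the read-out beyond the scatter. They also leave open whether hydroxy and methoxy would still match at other concentrations.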